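The source may hold more compounds than are shown below. What is called first, only, known or untested is meant among the compounds shown, and "the series" means these compounds.

Measured so far in an in vitro ADME assay on microsomes from liver (Homo sapiens) for pharmacokinetics, read by LC-MS, with a stated time of 10 min, tested at 1 uM; on this read-out lower numbers stand for slow clearance and higher numbers for fast clearance:
- compound 1 `CN1C[C@H](C(=O)Nc2ccc(F)cc2)[C@@H](c2ccc(/C=C/C(=O)Nc3ccccc3N)cc2)C1`: 5 mL/min/kg
- compound 2 `CN1C[C@H](C(=O)Nc2ccc(F)c(Cl)c2)[C@@H](c2ccc(/C=C/C(=O)Nc3ccccc3N)cc2)C1`: 15 mL/min/kg

Of these two, compound 2 has the higher number, 15 mL/min/kg, and so the faster clearance. The next compound, compound 3 `CN1C[C@H](C(=O)Nc2cccnc2)[C@@H](c2ccc(/C=C/C(=O)Nc3ccccc3N)cc2)C1`, has not been measured. The change is pyridin-3-yl in place of 3-chloro-4-fluorophenyl on an amide-type nitrogen.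

Within the data shown here, the only measured step that bears on this change is a 3.0-fold higher number from compound 1 to compound 2 (0.48 log units; beyond the scatter), a modest step beyond the scatter, with chloro in place of hydrogen on an aromatic carbon. Compound 3 carries no chloro, so a move back towards compound 1 at 5 mL/min/kg is expected. Among the measured compounds shown here, that reading is uncertain, since no measured compound carries pyridin-3-yl and the data do not show what this ring does in this assay. The expected step is a 2.5-fold lower number from compound 2 to compound 3 (0.40 log units; beyond the scatter), modest and towards a lower number. The estimate for compound 3 is 6 mL/min/kg, with an expected range of 3 mL/min/kg to 14 mL/min/kg.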

Compound 3, clearance: 10 mL/min/kg
Compound 3: middle estimate off by 1.7-fold (0.22 log units), on the low side; the range from low to high includes it.
By their numbers in this assay, from the lowest: compounds 1, 3 and 2 (each within the scatter of the next, the first and the last beyond it).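

In this assay, pyridin-3-yl in place of 3-chloro-4-fluorophenyl on the amide-type nitrogen gives a 1.5-fold lower number from compound 2 to compound 3 (0.18 log units; within the scatter) and pyridin-3-yl in place of 4-fluorophenyl gives a 2.0-fold higher number from compound 1 to compound 3 (0.30 log units; within the scatter), so on this read-out compound 3 cannot be told apart from either of the two compounds that carry a halogenated phenyl ring. Among these compounds, the position therefore accepts a six-membered aromatic ring with a hetero atom and one hydrogen-bond acceptor without a step beyond the scatter, and the only pair separated beyond the scatter remains the one that differs by chloro, with a 3.0-fold higher number from compound 1 to compound 2 (0.48 log units; beyond the scatter) as the sole clear step so far. Nothing measured here accounts for any of these numbers.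

On these data alone, it stays open whether chloro on the pyridin-3-yl ring would give a step like the one seen on the phenyl ring, and whether pyridin-2-yl or pyridin-4-yl would read like pyridin-3-yl. Also open, as far as these compounds go, is how a non-aromatic group on the same nitrogen, such as cyclohexyl or a short alkyl chain, would read in this clearance measurement.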